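Fluorophenyl swap on the shared core: cytotoxicity notes

The source may report more compounds than this note shows. Statements on the series, on what has been measured and on what is new or still open speak of the compounds shown alone.

Compound 1 `C/C(=C\CC/C(C)=C/CC[C@@H]1[C@@]2(C)CCC(=O)C(C)(C)[C@H]2CC[C@@]1(C)O)CC/C=C(\C)C(=O)OCc1cn(-c2cccc(O)c2)nn1`: in an ADME assay on L132 cells (Homo sapiens) for cytotoxicity, read by MTT assay, with a stated time of 48 h (on this read-out higher numbers stand for weaker inhibition and lower numbers for stronger inhibition), compound 1 gives 146000 nM.
Compound 2 `C/C(=C\CC/C(C)=C/CC[C@@H]1[C@@]2(C)CCC(=O)C(C)(C)[C@H]2CC[C@@]1(C)O)CC/C=C(\C)C(=O)OCc1cn(-c2ccc([N+](=O)[O-])cc2)nn1`: in this assay compound 2 gives > 150000 nM, a limit of the assay.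
Compound 3 `C/C(=C\CC/C(C)=C/CC[C@@H]1[C@@]2(C)CCC(=O)C(C)(C)[C@H]2CC[C@@]1(C)O)CC/C=C(\C)C(=O)OCc1cn(-c2ccc(F)cc2)nn1`: in this assay compound 3 gives > 150000 nM, again a limit of the assay.

Compound 3 therefore stands at the edge of what the assay can report, with only a bound known. Compound 4 `C/C(=C\CC/C(C)=C/CC[C@@H]1[C@@]2(C)CCC(=O)C(C)(C)[C@H]2CC[C@@]1(C)O)CC/C=C(\C)C(=O)OCc1cn(-c2ccccc2F)nn1` differs from compound 3 in one place: 2-fluorophenyl in place of 4-fluorophenyl on an aromatic nitrogen. The measured steps touching this aryl group are an at least 1.0-fold higher number from compound 1 to compound 2 (0.01 log units; that floor lies within the scatter) and an at least 1.0-fold higher number from compound 1 to compound 3 (0.01 log units; that floor lies within the scatter), both floors that sit within the scatter, while a step that the two limits leave unreadable from compound 2 to compound 3. Because (the limit of > 150000 nM in this assay, at which 2 of the 3 values shown sit), no direction can be read for the change to compound 4, and no step beyond the scatter is expected. Compound 4 is estimated at 150000 nM, between 90000 nM and 300000 nM. For compound 4 this is expected to mean a number no higher from compound 3 to compound 4 (the limit leaves the size open).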

Compound 4, half-maximal inhibitory concentration: > 150000 nM
Compound 4 ended at the assay's limit; the forecaster's own chance of this, stated with the estimate: 65%; the middle value lies on the limit itself.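

Compound 4 gives only a limit in this assay, not a number, so 2-fluorophenyl adds no readable value at this position. Among these compounds, the steps among compound 2, compound 3 and compound 4 cannot be read, and the only readable step is an at least 1.0-fold higher number from compound 1 to compound 4 (0.01 log units; that floor lies within the scatter). The two fluorophenyl isomers therefore cannot be told apart, and the limit now covers most of the set: the limit of > 150000 nM in this assay, at which 3 of the 4 values shown sit.

Going by these compounds, whether an amine or a carboxylic acid on this phenyl ring would give a value short of the limit stays open. So does any real ranking of the aryl groups.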